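From compound 3 to compound 4: bromo for methyl

This account rests on a few compounds, and the source may have more. Where it says the series, first, only, none or still open, it means among the compounds named here.

In an ADME assay on MT4 cells (Homo sapiens) for cytotoxicity, read by MTT assay (on this read-out higher numbers stand for lower toxicity in this test and lower numbers for higher toxicity in this test), compound 3 (`Cc1ccccc1NC(=O)CSc1nncnc1-c1cccc2ccccc12`) gives 158000 nM. Compound 1 (`Cc1ccc(NC(=O)CSc2nncnc2-c2cccc3ccccc23)c(Br)c1`) gives 166000 nM, and compound 2 (`Cc1cnc(NC(=O)CSc2nncnc2-c2ccccc2Cl)c(Br)c1`) gives 144000 nM, so compound 3 lies within the scatter of both. Compound 4 (`O=C(CSc1nncnc1-c1cccc2ccccc12)Nc1ccccc1Br`) differs from compound 3 in one place: bromo in place of methyl on an aromatic carbon. This puts bromo in place of methyl on an aromatic carbon, ortho to a large group. Among the measured compounds shown here, the one measured step that bears on this change, a 1.1-fold lower number from compound 1 to compound 3 (0.02 log units; within the scatter), removes the bromo of compound 1 together with its second methyl and stays within the scatter. No step beyond the scatter is therefore expected in this assay, and the estimated step is a 1.0-fold lower number from compound 3 to compound 4 (0.01 log units; within the scatter). For compound 4 the expected value is 155000 nM, with an estimated range of 90000 nM to 240000 nM.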

Compound 4, half-maximal cytotoxic concentration: 87000 nM
Beside the measured number, compound 4's estimate is 1.8-fold (0.25 log units) above it; measured number outside the range, below it.
By their numbers in this assay, from the lowest: compounds 4, 2, 3 and 1 (each within the scatter of the next).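

In this assay, among the compounds shown here, bromo and methyl at this place, on an aromatic carbon ortho to a large group, can be compared directly for the first time, and the exchange stays within the scatter (that is, a 1.8-fold lower number from compound 3 to compound 4 (0.26 log units; within the scatter)). The second methyl of compound 1 can now also be read on its own, and hydrogen in its place stays within the scatter too (that is, a 1.9-fold lower number from compound 1 to compound 4 (0.28 log units; within the scatter)). Nothing available gives a reason for either step. From the compounds shown here alone, whether an amine, a carboxylic acid or a methoxy group at this place would also stay within the scatter remains open.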